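The compounds below may be only part of what the source reports. "The series", "measured", "known", "first", "only" and "open" are said of these compounds alone.

In an ADME assay on CHO cells (Cricetulus griseus) for cytotoxicity, read by LDH release (a higher number here means a weaker inhibitor, a lower number a stronger inhibitor), three related compounds have been examined so far. For compound 1 (`CC(Oc1ccc(Cl)cc1Cl)C(=O)Nc1ccc(F)cc1`) the entry is "not determined" (no result reported) and for compound 2 (`CC(Oc1ccc(Cl)cc1Cl)C(=O)NCCCc1ccc(F)cc1`) it is "not determined" (no result reported) as well. Among the compounds with values here, compound 3 (`CC(Oc1ccc(Cl)cc1Cl)C(=O)NCc1ccccc1`) gives 95000 nM as the only number available, which leaves nothing to rank it against. Compound 4 (`Cc1ccc(CNC(=O)C(C)Oc2ccc(Cl)cc2Cl)cc1`) differs from it by methyl in place of hydrogen on an aromatic carbon, para to a large group (methyl in place of hydrogen on an aromatic carbon). Within the data shown here, no measured pair yet shows what such a change does in this assay. The estimated step of a 1.1-fold lower number from compound 3 to compound 4 (0.05 log units; within the scatter) is expected to stay within the scatter, with no firm direction. Compound 4 is expected at 85000 nM with 40000 nM to 170000 nM as its estimated range.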

Compound 4, half-maximal inhibitory concentration: 25000 nM
Beside the measured number, compound 4's estimate is 3.4-fold (0.53 log units) above it, outside the stated range (below it).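

This first measured pair in this assay shows that the ring position para to a large group is not silent: going from phenyl to 4-methylphenyl, with methyl in place of hydrogen on an aromatic carbon, gives a 3.8-fold lower number from compound 3 to compound 4 (0.58 log units; beyond the scatter) in the direction of a stronger inhibitor. A single added carbon is enough to move the result beyond the scatter. Nothing available accounts for the size or direction of this step. On these data alone, whether an ethyl group, a methoxy group or a chlorine at the same place would extend this step or reverse it remains open, as does whether a methyl elsewhere on the ring would do the same.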